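A few compounds are considered here, and "the series" means these few. Any claim that something is new, unique, unknown or untested is made for them only; others in the source may bear on it.

In an ADME assay (liver) for metabolic stability, with Liver microsome (Canis lupus familiaris) as the target, read by LC-MS, using microsomes, with a stated time of 30 min, tested at 4 uM (a lower number here means that less of the compound is left, a higher number that more of the compound is left), compound 1 `COc1cccc(-c2nc3c(N4CCN(C)CC4)nc(C)nc3n2C2CCOCC2)c1` gives 46%, while compound 2 `Cc1nc(N2CCN(C)CC2)c2nc(-c3ccccc3F)n(C3CCOCC3)c2n1` gives 21%, the lower of the two numbers. Compound 3 `COc1ccc(-c2nc3c(N4CCN(C)CC4)nc(C)nc3n2C2CCOCC2)c(C)c1` has not yet been measured. It carries 4-methoxy-2-methylphenyl in place of 2-fluorophenyl on an aromatic carbon. Among the compounds with values here, one measured step bears on this change, made at the same place, where 2-fluorophenyl took the place of 3-methoxyphenyl: a number 25 percentage points lower from compound 1 to compound 2 (beyond the scatter). That step was modest but beyond the scatter. Within the data shown here, compound 3 again has a methoxy-bearing phenyl, so part of that step may be recovered, but 4-methoxy-2-methylphenyl itself appears in no measured compound, and the evidence is thin. The expected change is a number 14 percentage points higher from compound 2 to compound 3 (beyond the scatter), a modest rise. For compound 3 the estimated value is 35%, with an expected range of 16% to 55%.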

Compound 3, percent of the compound remaining: 41%
Estimate against measurement, compound 3: 6 percentage points below, within the range that was stated.
By their numbers in this assay, from the lowest: compound 2; then compounds 3 and 1 (each within the scatter of the next).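

At this aromatic carbon, between two ring nitrogen atoms, exchanging 2-fluorophenyl for 4-methoxy-2-methylphenyl gives in this assay a number 20 percentage points higher from compound 2 to compound 3 (beyond the scatter) and so shows that the low number of compound 2 is not shared by every ortho-free or substituted aryl tried here. Set against 3-methoxyphenyl, the same group gives a number 5 percentage points lower from compound 1 to compound 3 (within the scatter) in this assay, so the two methoxy-bearing phenyl groups cannot be told apart, and among these three compounds only compound 2, the one without a methoxy group, stands apart. The data offer no measured explanation for this difference.

Within the data shown here, whether the fluorine, the methoxy group or the methyl group decides the outcome remains open, as no pair here isolates one of them. Also open, from the compounds shown here alone, is how a plain phenyl, a pyridine ring or a carboxylic acid at this carbon would read.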